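The compounds below may be only part of what the source reports. "The series", "measured", "known", "first", "only" and "open" are said of these compounds alone.

Measured so far in an ADME assay on C8166 cells (Homo sapiens) for inhibition, read by MTT assay, with a stated time of 72 h; a higher number here means that more compound is tolerated, a lower number that less compound is tolerated:

- compound 1, `O=c1cc(-c2ccccc2)oc2cc(OCc3ccc(F)cc3)cc(O)c12`: 8.35 ug/mL
- compound 2, `CC(C)(C)Oc1cc(O)c2c(=O)cc(-c3ccccc3)oc2c1`: 61.2 ug/mL
- compound 3, `O=c1c(-c2ccc(O)cc2)coc2cc(OCc3ccc(F)cc3)cc(O)c12`: > 200 ug/mL

Compound 1 and compound 2 share a core and differ only by tert-butyl in place of 4-fluorobenzyl on an oxygen on an aromatic ring. That change gives a 7.3-fold higher number from compound 1 to compound 2 (0.87 log units; beyond the scatter), so compound 2 is tolerated at a clearly higher concentration than compound 1 in this assay. Compound 3 carries a different core; the difference between the two cores is not broken down here. For the measured compounds named here, for compound 3 this assay reports only a limit, > 200 ug/mL, and this is the one value that sits at the limit of > 200 ug/mL in this assay, at which 1 of the 3 values shown sits.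

Compound 4, `CC(C)(C)Oc1cc(O)c2c(=O)c(-c3ccc(O)cc3)coc2c1`, is not yet measured. It stands to compound 3 as compound 2 stands to compound 1: the change is tert-butyl in place of 4-fluorobenzyl on an oxygen on an aromatic ring, made at the same place in the same words, so it is the same change seen once before. From compound 3 to compound 4 a step of the same kind is expected, a step that the limit leaves unreadable from compound 3 to compound 4, because the same change gave a 7.3-fold higher number from compound 1 to compound 2 (0.87 log units; beyond the scatter) in this assay. Since compound 3 already sits at the limit, compound 4 is expected most likely to come back as a limit as well, and the true value of compound 4 is estimated to lie around 400 ug/mL, between 150 ug/mL and 1500 ug/mL.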

Compound 4, half-maximal cytotoxic concentration: 47.7 ug/mL
The estimate for compound 4 lay 8.4-fold (0.92 log units) above the measured number; measured number outside the range, below it.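

Tert-butyl in place of 4-fluorobenzyl on an oxygen on an aromatic ring gives an at least 4.1-fold lower number from compound 3 to compound 4 (0.62 log units; beyond the scatter) in this assay, so the change does not carry its direction from the core of compound 1 to the core of compound 3: the same change on two cores in this assay, a 7.3-fold higher number (0.87 log units; beyond the scatter) from compound 1 to compound 2 and an at least 4.1-fold lower number (0.62 log units; beyond the scatter) from compound 3 to compound 4, at least 30-fold (1.48 log units) apart, beyond the scatter of two such steps

Compound 3 reads only as a limit, > 200 ug/mL, so this step has a bound and no exact size: the limit of > 200 ug/mL in this assay, at which 1 of the 4 values shown sits.

The two pairs show that the outcome of this one change differs with the core in these four compounds, but they do not show which part of the difference between the cores is responsible, nor how the change would behave on any third core.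

Still open, from the compounds shown here alone, is whether other groups on the same oxygen, such as a longer chain or a chain ending in an amine or a carboxylic acid, would follow the pair on the core of compound 1 or the pair on the core of compound 3. For the compounds shown here, also open is how far apart the two steps truly lie, as that gap rests on a limit and only two cores appear here.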